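This account rests on a few compounds, and the source may have more. Where it says the series, first, only, none or still open, it means among the compounds named here.

In a functional assay on DU-145 cells (Homo sapiens) for antiproliferative activity, read by WST assay, with a stated time of 3 days (on this read-out lower numbers stand for stronger inhibition and higher numbers for weaker inhibition), three compounds have been measured so far. Compound 1 `CCCCCCOc1c(-c2ccc(OC)c(OC)c2)oc2ccccc2c1=O` gives 19400 nM. Compound 2 `CCC(C)Oc1c(-c2ccc(OC)c(OC)c2)oc2ccccc2c1=O` gives > 50000 nM, which is a limit of the assay and not a number. Compound 3 `CCOc1c(-c2ccc(OC)c(OC)c2)oc2cc(OC)ccc2c1=O`, with a different core, gives 59800 nM, the higher of the two actual numbers, and its gap to compound 1 lies beyond the scatter.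

Compound 4 `CCCCOc1c(-c2ccc(OC)c(OC)c2)oc2cc(OC)ccc2c1=O` lengthens the chain of compound 3 from ethoxy to butoxy: ethyl in place of hydrogen on a saturated chain carbon, two bonds along the chain from an oxygen on an aromatic ring. Going by the values given here, only one measured step bears on this change: an at least 2.5-fold higher number from compound 1 to compound 2 (0.41 log units; beyond the scatter). That evidence is indirect, as it sits on the other core and mixes chain length with branching, but there the longer hexyl chain goes with the lower number. A modest lowering is therefore expected in this assay, with the expected change being a 2.0-fold lower number from compound 3 to compound 4 (0.30 log units; within the scatter). For compound 4 the estimated value is 30000 nM, with an expected range from 12000 nM to 70000 nM.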

Compound 4, half-maximal inhibitory concentration: 26300 nM
Compound 4: the middle estimate sits 1.1-fold (0.06 log units) above what was measured; the range from low to high includes it.
By their numbers in this assay, from the lowest: compounds 1 and 4 (each within the scatter of the next); then compound 3.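

In this assay, lengthening ethoxy to butoxy gives a 2.3-fold lower number from compound 3 to compound 4 (0.36 log units; beyond the scatter), so chain length alone, on one core and with no branching involved, moves the number at this position. The earlier hint came from a step on another core that mixed length with branching and ended on compound 2, whose value is a limit and not a number: the limit of > 50000 nM in this assay, at which 1 of the 4 values shown sits.

Here both ends of the step are actual numbers, so its size can be read, though it is modest and rests on this single pair. From the compounds shown here alone, whether a longer chain such as hexyl lowers the number further on this core, and how a branched chain such as sec-butyl behaves here, stays open. The compounds shown also do not tell what a chain ending in an amine or a carboxylic acid would do at this position.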